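A few compounds are considered here, and "the series" means these few. Any claim that something is new, unique, unknown or untested is made for them only; others in the source may bear on it.

In a functional assay on HepG2 cells (Homo sapiens) for inhibition, read by scintillation counting, with a stated time of 2 h (on this read-out lower numbers stand for stronger inhibition and higher numbers for weaker inhibition), compound 1 (`CCCC(=O)N1CCC(N2CCN(C(=O)c3c(NC(=O)NCC)sc4ccccc34)CC2)CC1`) is reported as "not determined" (no result reported). Compound 2 (`CCNC(=O)Nc1sc2ccccc2c1C(=O)N1CCN(C2CCN(C(=O)C(C)(C)C)CC2)CC1`) gives 450 nM. Compound 3 (`CCNC(=O)Nc1sc2ccccc2c1C(=O)N1CCN(C2CCN(C(=O)OC(C)C)CC2)CC1`) gives 208 nM, the lower of the two numbers available. Compound 4 (`CCNC(=O)Nc1sc2ccccc2c1C(=O)N1CCN(C2CCN(C(=O)OC3CCCC3)CC2)CC1`) differs from compound 3 by one change, cyclopentyl in place of isopropyl on an oxygen next to a carbonyl group. Among the measured compounds shown here, the one measured step that bears on this, a 2.2-fold lower number from compound 2 to compound 3 (0.34 log units; beyond the scatter), swapped isopropoxy for tert-butyl on a carbonyl carbon and was modest. For the measured compounds named here, no measured compound carries a ring in this group, so the direction remains open. In this assay no step beyond the scatter is therefore expected, and the estimated step is a 1.2-fold lower number from compound 3 to compound 4 (0.09 log units; within the scatter). For compound 4 the estimated value is 170 nM, within an expected range of 70 nM to 420 nM.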

Compound 4, half-maximal inhibitory concentration: 512 nM
Estimate against measurement, compound 4: 3.0-fold (0.48 log units) below, and the stated range ends below it.
By their numbers in this assay, from the lowest: compound 3; then compounds 2 and 4 (each within the scatter of the next).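

In this assay, the oxygen next to a carbonyl group proves sensitive to the group it carries: putting cyclopentyl, with its five-membered ring of carbon, in place of isopropyl gives a 2.5-fold higher number from compound 3 to compound 4 (0.39 log units; beyond the scatter). Cyclopentyloxy and tert-butyl on the carbonyl carbon cannot be told apart, with a 1.1-fold higher number from compound 2 to compound 4 (0.06 log units; within the scatter), so the advantage of compound 3 does not carry over to this ring. Nothing available explains this loss of inhibition.

Still open, as far as these compounds go, is whether the ring itself or the added carbons matter. A cyclopropyl group or an open chain such as n-pentyl on the same oxygen would help separate the two.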